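Bromo in Place of Iodo on the Five-Membered Ring

The source may hold more compounds than are shown below. What is called first, only, known or untested is meant among the compounds shown, and "the series" means these compounds.

Three chalcones built on a shared chloroquinoline-like core have been measured in a functional assay on HUVEC cells (Homo sapiens), read by BrdU incorporation, with a stated time of 72 h; a higher number here means a weaker inhibitor, a lower number a stronger inhibitor. Compound 1 `Cc1ccc2cc(/C=C/C(=O)c3ccc(Br)s3)c(Cl)nc2c1` gives 83.6 nM in this assay. Compound 2 `Cc1cccc2cc(/C=C/C(=O)c3ccc(Cl)s3)c(Cl)nc12` gives 116 nM, and compound 3 `Cc1ccc2nc(Cl)c(/C=C/C(=O)c3ccc(I)s3)cc2c1` gives 129 nM. Of the three numbers, that of compound 3 is the highest, yet its gaps to compound 2 and to compound 1 both fall within the usual scatter of this assay, so the three compounds cannot be told apart on these data.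

Compound 4 `Cc1ccc2nc(Cl)c(/C=C/C(=O)c3ccc(Br)s3)cc2c1` differs from compound 3 in a single place: bromo in place of iodo on an aromatic carbon. Within the data shown here, no pair of measured compounds shares exactly this change, so no measured step can be carried over. Compound 1 carries a bromo group on the same five-membered ring and gives 83.6 nM, but its core is substituted differently, so it offers only a loose reference.

The step from compound 3 to compound 4 in this assay is expected to be a 1.2-fold lower number from compound 3 to compound 4 (0.09 log units; within the scatter), that is, nothing beyond the scatter. Compound 4 is therefore estimated at 105 nM, with a range from 50 nM to 220 nM.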

Compound 4, half-maximal inhibitory concentration: 88.4 nM
Estimate against measurement, compound 4: 1.2-fold (0.07 log units) above; the measured number falls inside the stated range.
By their numbers in this assay, from the lowest: compounds 1, 4, 2 and 3 (each within the scatter of the next).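

In this assay, going from 5-iodothiophen-2-yl to 5-bromothiophen-2-yl gives a 1.5-fold lower number from compound 3 to compound 4 (0.16 log units; within the scatter), the first step measured at this place on the five-membered ring. Among these compounds, on this core, then, the exchange of iodo for bromo next to the ring sulfur leaves a change that cannot be told from the scatter, something the earlier compounds could not show, as no two of them differ in one place alone. Nothing measured here speaks to what lies behind this result.

The compounds shown leave open how an amine, a methoxy group or a carboxylic acid would read at this place, since only iodo, bromo and chloro stand there. Also open, from the compounds shown here alone, is whether the same exchange would give a similar step on the cores of compound 1 and compound 2.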